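Buffer stability of a bis(trifluoromethyl)phenyl series

The compounds below may be only part of what the source reports. "The series", "measured", "known", "first", "only" and "open" are said of these compounds alone.

Measured so far in an ADME assay for pharmacokinetics, read by HPLC, in phosphate buffer, with a stated time of 72 h, at pH 7.4, tested at 250 uM; on this read-out lower numbers stand for a shorter-lived compound and higher numbers for a longer-lived compound:
Compound 1, `C=CC(=O)Oc1cc(C(F)(F)F)cc(C(F)(F)F)c1`: compound 1 gives < 0.017 h, which is a limit of the assay.
Compound 2, `C#Cc1cc(C(F)(F)F)cc(C(F)(F)F)c1`: compound 2 gives > 50 h, also a limit.
Compound 3, `O=C(CBr)c1cc(C(F)(F)F)cc(C(F)(F)F)c1`: compound 3 gives < 0.017 h, again a limit.

Compound 3 therefore stands at the low end of the numbers shown, sharing the limit of < 0.017 h in this assay, at which 2 of the 3 values shown sit, with compound 1, while only compound 2 reaches (the limit of > 50 h in this assay, at which 1 of the 3 values shown sits). The measured steps are an at least 2900-fold higher number from compound 1 to compound 2 (3.46 log units; beyond the scatter) and an at least 2900-fold lower number from compound 2 to compound 3 (3.46 log units; beyond the scatter), both large; a step that the two limits leave unreadable from compound 1 to compound 3 cannot be sized, as both ends sit at limits.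

Compound 4, `FC(F)(F)c1cc(C2CO2)cc(C(F)(F)F)c1`, is not yet measured in this assay. It differs from compound 3 by oxiran-2-yl in place of (bromomethyl)carbonyl on an aromatic carbon. Among the measured compounds shown here, no measured step exchanges the (bromomethyl)carbonyl for an oxiran-2-yl group, so none of the steps sets the size of this change directly. Since compound 3 already sits at the low limit with < 0.017 h, the number for compound 4 can only be expected to be equal or higher, and a move away from that limit is expected. Compound 4 is estimated at 30 h, with a range from 5 h to 150 h. The expected step is an at least 1700-fold higher number from compound 3 to compound 4 (3.24 log units; beyond the scatter), with a real chance that the assay again reports only a limit.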

Compound 4, half-life: 6 h
The estimate for compound 4 lay 5.0-fold (0.70 log units) above the measured number; the measured number falls inside the stated range.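

In this assay, among the compounds shown here, the oxiran-2-yl group on an aromatic carbon, meta to two trifluoromethyl groups, gives the first value that is a number rather than a limit, with compound 4 at 6 h. Putting oxiran-2-yl in place of (bromomethyl)carbonyl gives an at least 350-fold higher number from compound 3 to compound 4 (2.54 log units; beyond the scatter), and putting it in place of (vinylcarbonyl)oxy gives an at least 350-fold higher number from compound 1 to compound 4 (2.54 log units; beyond the scatter), so at this position a group other than ethynyl also clears the low limit, where the two compounds with the carbonyl-bearing groups stay: the limit of < 0.017 h in this assay, at which 2 of the 4 values shown sit. Putting oxiran-2-yl in place of ethynyl gives an at least 8.3-fold lower number from compound 2 to compound 4 (0.92 log units; beyond the scatter), which places compound 4 under the only compound at the high limit and shows that the series has a measurable middle: the limit of > 50 h in this assay, at which 1 of the 4 values shown sits.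

On these data alone, all three steps remain bounds, and the true distance of compound 4 from compounds 1, 2 and 3 stays unknown while those three sit at limits. The compounds shown also leave open what an amine, a carboxylic acid or a longer chain on the same aromatic carbon would give, and whether substitution on the oxiran-2-yl ring would move the half-life.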